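The source may hold more compounds than are shown below. What is called first, only, known or untested is meant among the compounds shown, and "the series" means these compounds.

Measured so far in this study:
compound 1, `O=C(/C=C1\CCc2ccc(F)cc21)NC1CCC1`: 0%
compound 2, `CCN(C)C(=O)/C=C1\CCc2ccc(F)cc21`: 44%
compound 3, `O=C(/C=C1\CCc2ccc(F)cc21)N1CCC1`: 0%

All three were tested in a functional assay on the whole organism with Rattus norvegicus as the target, at a dose of 20 mg/kg by the oral route; a lower number here means less inhibition, a higher number more inhibition at the dose given (going by the name of the read-out). Among the measured compounds shown here, compound 3 stands level with compound 1, and together these two give the lowest numbers of the three; compound 2 gives the only clearly higher number. The two steps that lead to compound 3 show this: no change at the digits printed from compound 1 to compound 3 (within the scatter), whereas a number 44 percentage points lower from compound 2 to compound 3 (beyond the scatter).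

The next compound is compound 4, `CCCNC(=O)/C=C1\CCc2ccc(F)cc21`. Its change from compound 3 is: propylamino in place of azetidin-1-yl on a carbonyl carbon. Compound 4 thus carries a hydrogen-bond donor, as compound 1 does, while having no ring, as compound 2 has none. For the measured compounds named here, no measured step joins a donor-bearing amide to an open-chain one, so the two steps above pull in opposite directions and give only a rough guide.

For compound 4 an inhibition near 10% is expected, with a range from 0% to 35%. The step of a number 10 percentage points higher from compound 3 to compound 4 (within the scatter) is therefore expected to be small, if beyond the scatter at all.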

Compound 4, a percentage reported as inhibition, in the whole organism at one dose (the size of the read-out at that dose, not a potency): 36%
Estimate against measurement, compound 4: 26 percentage points below; the measured number lies above the stated range.
By their numbers in this assay, from the lowest: compounds 1 and 3 (each within the scatter of the next); then compounds 4 and 2 (each within the scatter of the next).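

In this assay, keeping the amide hydrogen while putting propyl in place of cyclobutyl gives a number 36 percentage points higher from compound 1 to compound 4 (beyond the scatter) and so the presence of that hydrogen does not by itself go with a low number. Propylamino, with the same count of heavy atoms as azetidin-1-yl, gives a number 36 percentage points higher from compound 3 to compound 4 (beyond the scatter) on the same carbonyl carbon, whereas propylamino in place of ethyl(methyl)amino gives only a number 8 percentage points lower from compound 2 to compound 4 (within the scatter) and so the two open-chain amides stay together with or without the amide hydrogen. Among these four compounds, the two amides carrying a four-membered ring give the low numbers and the two without a ring the higher ones, with no compound going against this, but no measurement here explains it.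

Going by these compounds, it remains open whether a larger ring, as in piperidin-1-yl, would also go with a low number. A longer chain, as in hexylamino, could show how far the open-chain result extends.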